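The source may report more compounds than this note shows. Statements on the series, on what has been measured and on what is new or still open speak of the compounds shown alone.

Measured so far:
Compound 1, `CC(=O)OCC(C)(C)NC(=O)N(CCC1CCN(Cc2ccc(C)cc2)CC1)Cc1ccc(-c2ccc(F)cc2)cc1`: 92.3%
Compound 2, `Cc1ccc(CN2CCC(CCN(Cc3ccc(-c4ccc(F)cc4)cc3)C(=O)NC(C)(C)CO)CC2)cc1`: 102%

In an in vitro functional assay on HEK293 cells for antagonist activity at melanin-concentrating hormone receptor 1 (Homo sapiens) (a higher number here means a larger maximal response, a lower number a smaller maximal response), compound 2 gives 102%, the highest of the two numbers, with compound 1 as its nearest neighbour at 92.3%, a gap that lies within the scatter. Compound 3, `CCC(CO)(CO)NC(=O)N(CCC1CCN(Cc2ccc(C)cc2)CC1)Cc1ccc(-c2ccc(F)cc2)cc1`, differs from compound 2 in one place: 1,1-bis(hydroxymethyl)propyl in place of 1-(hydroxymethyl)-1-methylethyl on an amide-type nitrogen. Going by the values given here, the only measured step that touches this part of the molecule is a number 9.7 percentage points higher from compound 1 to compound 2 (within the scatter), which also altered the group carrying the hydroxymethyl and left the maximal response unchanged within the scatter. Compound 3 keeps one hydroxymethyl and brings in a second, and nothing measured argues for a gain or a loss in this assay, while the number for compound 2 already sits at the level of the reference. The expected step is therefore a number 4 percentage points lower from compound 2 to compound 3 (within the scatter), none beyond the scatter. Compound 3 is estimated at 98%, with a range from 85% to 110%.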

Compound 3, largest response reached (reported as Imax), in percent of the reference or control that the assay uses: 111%
Compound 3: the middle estimate sits 13 percentage points below what was measured, and the stated range ends below it.
By their numbers in this assay, from the lowest: compounds 1, 2 and 3 (each within the scatter of the next, the first and the last beyond it).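

In this assay the step of a number 9 percentage points higher from compound 2 to compound 3 (within the scatter) shows that 1,1-bis(hydroxymethyl)propyl can replace 1-(hydroxymethyl)-1-methylethyl on the amide-type nitrogen with no change that stands clear of the scatter, even though the group is larger and carries a second hydroxymethyl. Going by these compounds alone, the step of a number 18.7 percentage points higher from compound 1 to compound 3 (beyond the scatter) is the first at this position to pass the scatter, although the two steps that connect these compounds through compound 2 each stay within it. Nothing available offers an explanation for either step.

The compounds shown do not separate what the second hydroxymethyl contributes from what the longer carbon chain contributes, as both enter together in compound 3. They also leave open how this position would respond to an amine or a carboxylic acid in place of a hydroxymethyl.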